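A Fluoropyridine Takes the Place of a Cyanofluorophenyl Group

A few compounds are considered here, and "the series" means these few. Any claim that something is new, unique, unknown or untested is made for them only; others in the source may bear on it.

Three measured compounds share one core. In an in vitro functional assay on HEK285-7 cells for antagonist activity at prostaglandin D2 receptor 2 (Homo sapiens), read by BRET and beta-arrestin recruitment (on this read-out higher numbers stand for weaker inhibition and lower numbers for stronger inhibition), compound 1 `O=C(O)Cc1sc(CSc2ccccc2)nc1-c1ccc(Cl)cc1` gives 450 nM, compound 2 `O=C(O)Cc1sc(CS(=O)(=O)c2ccc(Cl)cc2)nc1-c1ccc(Cl)cc1` gives 730 nM, and compound 3 `N#Cc1cc(-c2nc(C(c3ccc(F)cc3)c3ccc(F)cc3)sc2CC(=O)O)ccc1F` gives 520 nM. All three numbers lie within the usual scatter of one another, so no one of them can be ranked against the others. Compound 4 `O=C(O)Cc1sc(C(c2ccc(F)cc2)c2ccc(F)cc2)nc1-c1ccnc(F)c1` differs from compound 3 in a single place: 2-fluoropyridin-4-yl in place of 3-cyano-4-fluorophenyl on an aromatic carbon. Within the data shown here, no measured pair shows this exchange, so there is no step to lean on. Compound 3 gives 520 nM in this assay , and compound 4 is expected to stay close to that number, estimated at 650 nM with a range from 250 nM to 1800 nM. The step of a 1.3-fold higher number from compound 3 to compound 4 (0.10 log units; within the scatter) is expected to remain within the scatter.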

Compound 4, half-maximal inhibitory concentration: 4.7 nM
Beside the measured number, compound 4's estimate is 140-fold (2.14 log units) above it; measured number outside the range, below it.
By their numbers in this assay, from the lowest: compound 4; then compounds 1, 3 and 2 (each within the scatter of the next).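

Among these compounds, this position on the shared core proves highly sensitive: in this assay, 2-fluoropyridin-4-yl in place of 3-cyano-4-fluorophenyl gives a 110-fold lower number from compound 3 to compound 4 (2.04 log units; beyond the scatter), a large step that the earlier compounds, with no single-place pair among them, could not show. Both groups are six-membered aromatic rings bearing fluorine, yet the one with a ring nitrogen and no nitrile has the far lower number. No measured evidence here accounts for this step.

The two compounds cannot separate the part played by the ring nitrogen from that of the nitrile. Pyridin-4-yl without fluorine, or 2-chloropyridin-4-yl, at this position would test what the fluorine contributes.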